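The source may report more compounds than this note shows. Statements on the series, on what has been measured and on what is new or still open speak of the compounds shown alone.

Measured compounds:
- compound 1 `COc1ccccc1N1CCN(CCCCCCn2nc(-n3cnc4ccccc43)ccc2=O)CC1`: 6.4 nM
- compound 2 `O=c1ccc(-n2cnc3ccccc32)nn1CCCCN1CCN(c2ccccc2Cl)CC1`: 1.3 nM
- compound 3 `O=c1ccc(-n2cnc3ccccc32)nn1CCCCCCN1CCN(c2ccccc2Cl)CC1`: 15.1 nM

All three were tested in an assay on cell membranes from brain for binding affinity to Adrenergic receptor alpha-1 (Rattus norvegicus), read by radioligand binding; on this read-out lower numbers stand for stronger inhibition and higher numbers for weaker inhibition. Compound 1 holds the second highest number of the three; compound 3 sits nearest, and compound 2 furthest with the lowest number. Among the compounds with values here, the one single-point step known, a 2.4-fold higher number from compound 1 to compound 3 (0.37 log units; beyond the scatter), concerns the aryl ring on the far end of the chain, not the group on the shared core.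

Compound 4 `COc1ccccc1N1CCN(CCCCCCn2nc(-n3ccnc3)ccc2=O)CC1` differs from compound 1 by 1H-imidazol-1-yl in place of 1H-benzimidazol-1-yl on an aromatic carbon. Within the data shown here, no measured step touches this position, so nothing here indicates how the smaller ring will fare; the larger group is simply removed without a comparison to lean on. A modest weakening is expected, a 3.1-fold higher number from compound 1 to compound 4 (0.49 log units; beyond the scatter), giving compound 4 an estimated 20 nM with a range from 5 nM to 80 nM.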

Compound 4, inhibition constant: 52.5 nM
Beside the measured number, compound 4's estimate is 2.6-fold (0.42 log units) below it, and the stated range covers the measured number.
By their numbers in this assay, from the lowest: compound 2; then compound 1; then compound 3; then compound 4.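

In this assay, within the data shown here, the position on the shared core proves sensitive to its group: 1H-imidazol-1-yl in place of 1H-benzimidazol-1-yl gives an 8.2-fold higher number from compound 1 to compound 4 (0.91 log units; beyond the scatter) as the first measured step at this place. The entering group keeps the five-membered aromatic ring and lacks the six-membered aromatic ring of carbon only, and this loss goes with weaker inhibition. Nothing measured here gives a reason for the step. Still open, from the compounds shown here alone, is how an amine or a carboxylic acid would fare at this position. Also open, going by these compounds, is whether the same change gives a similar step with chloro on the far aryl ring.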